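The source may hold more compounds than are shown below. What is called first, only, known or untested is meant among the compounds shown, and "the series" means these compounds.

Working notes on the series.

Compound 1 `NS(=O)(=O)c1ccc(N2N=C(c3ccc(OCc4ccccc4)cc3)CC2c2ccc(F)cc2)cc1` carries a 4-fluorophenyl group on the saturated ring carbon of the shared core. In an ADME assay on MT4 cells (Homo sapiens) for cytotoxicity, read by MTT assay, with a stated time of 96 h (a lower number here means that less compound is tolerated, a higher number that more compound is tolerated), compound 1 gives > 100000 nM, which is a limit of the assay and not a number. Compound 2 `NS(=O)(=O)c1ccc(N2N=C(c3ccc(Oc4ccccc4)cc3)CC2c2ccccc2Cl)cc1` carries a 2-chlorophenyl group and a phenoxy group, and in this assay compound 2 gives 40000 nM. Compound 3 `Cc1ccccc1C1CC(c2ccc(OCc3ccccc3)cc2)=NN1c1ccc(S(N)(=O)=O)cc1` carries a 2-methylphenyl group on the saturated ring carbon. In this assay compound 3 gives >= 100000 nM, again a limit of the assay. Compound 3 therefore stands at the upper edge of what the assay reports; the step that the two limits leave unreadable from compound 1 to compound 3 cannot be read, since both ends sit at limits (the limit of > 100000 nM in this assay, at which 1 of the 3 values shown sits, (the limit of >= 100000 nM in this assay, at which 1 of the 3 values shown sits)).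

Compound 4 `NS(=O)(=O)c1ccc(N2N=C(c3ccc(OCc4ccccc4)cc3)CC2c2ccccc2Cl)cc1` is the next member. From compound 3 the change is chloro in place of methyl on an aromatic carbon. Going by the values given here, no measured step bears directly on this change; the only other compound with a 2-chlorophenyl group is compound 2, whose value in this assay is a number while compound 3 sits at a limit, and the two differ elsewhere as well.

The step of an at least 1.4-fold lower number from compound 3 to compound 4 (0.15 log units; that floor lies within the scatter) is expected to stay modest and may again land at a limit. Compound 4 is estimated at 70000 nM, within 30000 nM to 150000 nM.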

Compound 4, half-maximal cytotoxic concentration: 26000 nM
Beside the measured number, compound 4's estimate is 2.7-fold (0.43 log units) above it; the measured number lies below the stated range.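

In this assay, going by these compounds alone, chloro in place of methyl on an aromatic carbon gives the first step at this position with a readable direction, an at least 3.8-fold lower number from compound 3 to compound 4 (0.58 log units; beyond the scatter), and swapping the 4-fluorophenyl group on the saturated ring carbon for a 2-chlorophenyl group gives an at least 3.8-fold lower number from compound 1 to compound 4 (0.58 log units; beyond the scatter). Both sizes are only floors, and compound 1 and compound 3 each stand at a limit of the assay and not at a number: the limit of >= 100000 nM in this assay, at which 1 of the 4 values shown sits. With the 2-chlorophenyl group held, benzyl in place of phenyl on an oxygen on an aromatic ring gives a 1.5-fold lower number from compound 2 to compound 4 (0.19 log units; within the scatter), so this change does not separate the two compounds, and in this small set only the two compounds with a 2-chlorophenyl group, compound 2 and compound 4, carry numbers rather than limits.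

Going by these compounds, how far the true gap from the methyl compound runs stays open, as does whether the lower number follows chloro at this place or would also appear with chloro elsewhere on that ring. Where a methoxy group, a hydroxy group or an amine on the same aromatic carbon would fall in this assay also stays open.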